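Moving one methyl group: what to expect for compound 4

A few compounds are considered here, and "the series" means these few. Any claim that something is new, unique, unknown or untested is made for them only; others in the source may bear on it.

Measured so far in a functional assay on MDA-MB-231 cells (Homo sapiens) for antiproliferative activity, read by MTT assay, with a stated time of 24 h; a lower number here means a stronger inhibitor, a higher number a weaker inhibitor:
- compound 1 `O=C(NNc1cccc(Cl)c1)c1cccc(NS(=O)(=O)c2cnc(O)nc2O)c1`: 7760 nM
- compound 2 `CCCCOc1ccc(C(=O)NNC(=O)c2cccc(NS(=O)(=O)c3cnc(O)nc3O)c2)cc1`: 17000 nM
- compound 3 `Cc1ccccc1C(=O)NNC(=O)c1cccc(NS(=O)(=O)c2cnc(O)nc2O)c1`: 18100 nM

Compound 3 stands at the high end of these numbers, level with compound 2 and clear of compound 1. The next compound, compound 4 `Cc1ccc(C(=O)NNC(=O)c2cccc(NS(=O)(=O)c3cnc(O)nc3O)c2)cc1`, has 4-methylphenyl in place of 2-methylphenyl on a carbonyl carbon. Going by the values given here, the two compounds have the same atoms, joined differently, and no measurement so far compares these two groups directly.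

The closest evidence is a swap at that same carbonyl carbon, 2-methylphenyl in place of 4-butoxyphenyl, which gave a 1.1-fold higher number from compound 2 to compound 3 (0.03 log units; within the scatter). That is a larger change of group than the one at hand, yet it left this assay within the normal noise of repeated measurements. The other measured step, a 2.3-fold higher number from compound 1 to compound 3 (0.37 log units; beyond the scatter), is modest and alters a different part of the structure, so it bears less on this question, though it does warn that small shifts are possible.

No clear direction can be argued from three compounds, and the expected result is no step beyond the scatter. The estimated step is a 1.1-fold lower number from compound 3 to compound 4 (0.03 log units; within the scatter). For compound 4 the expected value is 17000 nM, with an estimated range of 8000 nM to 35000 nM.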

Compound 4, half-maximal inhibitory concentration: > 20000 nM
Compound 4 gave a limit, no number; the forecaster's own chance of this, stated with the estimate: 5%; middle value at least 1.1-fold (0.07 log units) from the limit.
By their numbers in this assay, from the lowest: compound 1; then compounds 2 and 3 (each within the scatter of the next). At a limit, above all of these: compound 4.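

In this assay compound 4 gives a limit of the assay, not a number: the limit of > 20000 nM in this assay, at which 1 of the 4 values shown sits.

Moving the methyl, with 4-methylphenyl in place of 2-methylphenyl on a carbonyl carbon, gives an at least 1.1-fold higher number from compound 3 to compound 4 (0.04 log units; that floor lies within the scatter), and methyl in place of butoxy on an aromatic carbon gives an at least 1.1-fold higher number from compound 2 to compound 4 (0.07 log units; that floor lies within the scatter), so neither floor shows on its own that these changes matter. The clearer reading is an at least 2.5-fold higher number from compound 1 to compound 4 (0.41 log units; beyond the scatter), which adds to the earlier step from compound 1 to compound 3: the change is beyond the scatter, and it holds for the methyl in either of the two places shown.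

Going by these compounds, the true size of the methyl move stays open, since compound 4 has no number that could be set against the value of compound 3. Also open, on these data alone, is how this assay would respond to an amine or a carboxylic acid in place of that methyl, or to a chloro group on the same ring of the (4-methylphenyl)carbonyl series.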